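The source may report more compounds than this note shows. Statements on the series, on what has been measured and on what is new or still open speak of the compounds shown alone.

Compound 1 `O=C(Nc1cccc(-c2ccccc2C(F)(F)F)c1)C(Cl)Cl`: 35900 nM
Compound 2 `O=C(Nc1cccc(-c2cccs2)c1)C(Cl)Cl`: > 50000 nM (a limit of the assay)

For the measured compounds named here, in a functional assay on KB 3-1 cells (Homo sapiens) for cytotoxicity, read by MTT assay, with a stated time of 68 h (a lower number here means a stronger inhibitor, a higher number a weaker inhibitor), compound 1 gives 35900 nM, the only actual number so far. Compound 2 is reported only as a limit, > 50000 nM. Compound 3 `O=C(Nc1cccc(-c2ccccc2Cl)c1)C(Cl)Cl` has chloro in place of trifluoromethyl on an aromatic carbon, ortho to a large group: chloro in place of trifluoromethyl on an aromatic carbon. Going by the values given here, no measured step covers this change, so no shift beyond the scatter is expected in this assay, and the estimate rests on compound 1 at 35900 nM. The expected change is a 1.1-fold higher number from compound 1 to compound 3 (0.05 log units; within the scatter). Compound 3 is estimated at 40000 nM, with an expected range of 20000 nM to 50000 nM.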

Compound 3, half-maximal inhibitory concentration: > 50000 nM
Compound 3: no number, only a limit (the forecaster's own chance of this, stated with the estimate: 35%); middle value at least 1.2-fold (0.09 log units) away from the limit.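

In this assay, chloro in place of trifluoromethyl on an aromatic carbon, ortho to a large group, gives an at least 1.3-fold higher number from compound 1 to compound 3 (0.14 log units; that floor lies within the scatter), so this place now has its first step, though only its floor can be read. Compound 3 is reported only as a limit, > 50000 nM. Of the groups shown at this place, only trifluoromethyl yields an actual number, and the readings are bounded by the assay: the limit of > 50000 nM in this assay, at which 2 of the 3 values shown sit.

The compounds shown leave open how far compound 3 lies past its limit. They also leave open whether a methoxy group or an amine on this carbon would give a lower number than compound 1.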